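The source may report more compounds than this note shows. Statements on the series, on what has been measured and on what is new or still open speak of the compounds shown alone.

Measured so far in a functional assay on MCF7 cells (Homo sapiens) for antiproliferative activity, read by MTT assay, with a stated time of 48 h; a higher number here means a weaker inhibitor, a lower number a stronger inhibitor
- compound 1 `CC(=O)N1N=C(c2ccc3ccccc3c2)OC1c1cccc(F)c1` gives 1.98 ug/mL
- compound 2 `CC(=O)N1N=C(c2ccc3ccccc3c2)OC1c1ccc([N+](=O)[O-])cc1` gives 7.59 ug/mL

Compound 2 at 7.59 ug/mL stands as the higher of the two numbers. Compound 3 `CC(=O)N1N=C(c2ccc3ccccc3c2)OC1c1ccncc1` carries pyridin-4-yl in place of 4-nitrophenyl on a saturated ring carbon. Within the data shown here, the only measured step at this place is a 3.8-fold higher number from compound 1 to compound 2 (0.58 log units; beyond the scatter), modest and with 4-nitrophenyl entering, so a step of similar or smaller size toward a lower number is expected in this assay. The expected step is a 1.9-fold lower number from compound 2 to compound 3 (0.28 log units; within the scatter). For compound 3 the estimated value is 4 ug/mL, with an expected range from 1.5 ug/mL to 11 ug/mL.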

Compound 3, half-maximal inhibitory concentration: 2.56 ug/mL
Compound 3: the middle estimate sits 1.6-fold (0.19 log units) above what was measured; low and high end bracket the measured number.
By their numbers in this assay, from the lowest: compounds 1 and 3 (each within the scatter of the next); then compound 2.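

In this assay the number at this saturated ring carbon moves with the group: pyridin-4-yl in place of 4-nitrophenyl gives a 3.0-fold lower number from compound 2 to compound 3 (0.47 log units; beyond the scatter) and so the high number does not extend to every six-membered aromatic ring here. Pyridin-4-yl in place of 3-fluorophenyl gives a 1.3-fold higher number from compound 1 to compound 3 (0.11 log units; within the scatter) and that step lies within the scatter, so among these three groups only 4-nitrophenyl stands apart. Nothing measured on these compounds explains the change.

Open, from the compounds shown here alone, is how a dimethylamino group, a carboxylic acid or a longer alkyl chain would read at this carbon. Also open, going by these compounds, is whether 3-nitrophenyl would match 4-nitrophenyl.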